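The source may hold more compounds than are shown below. What is called first, only, known or untested is meant among the compounds shown, and "the series" means these compounds.

Measured so far in a functional assay on HEK293T cells for agonist activity at histamine H2 receptor (Homo sapiens), read by beta-arrestin recruitment; on this read-out higher numbers stand for an effect only at larger amounts of compound and lower numbers for an effect already at smaller amounts:
- compound 1 `Cc1nc(N)sc1CCCN/C(N)=N/C(=O)N[C@H](C)c1ccccc1` gives 45.7 nM
- compound 2 `Cc1nc(N)sc1CCCN/C(N)=N/C(=O)NCC(C)CCc1ccccc1` gives 355 nM
- compound 3 `Cc1nc(N)sc1CCCN/C(N)=N/C(=O)NC(c1ccccc1)c1ccccc1` gives 331 nM

Compound 2 has the highest of the three numbers. Its value and that of compound 3 lie within the scatter of each other, so no order between the two can be claimed. The value of compound 1 sits well below that of compound 2, beyond the scatter, so compound 2 reads as the weaker of these two.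

Compound 4 `Cc1ccc(CC(C)CNC(=O)/N=C(\N)NCCCc2sc(N)nc2C)cc1` is built from the same atoms as compound 2, joined differently: 4-methylphenyl in place of benzyl on a saturated chain carbon, three bonds along the chain from an amide-type nitrogen. For the measured compounds named here, no measured pair in the set shows this kind of rearrangement, so nothing in the data sets its size. The side chain of compound 2 stays saturated and branched in compound 4, with one ring carbon substituent moved, and the three measured values span only a modest range. The step from compound 2 to compound 4 is therefore expected to be small, a 1.2-fold lower number from compound 2 to compound 4 (0.07 log units; within the scatter), in no firm direction beyond the scatter. Compound 4 is estimated at 300 nM, in the range 100 nM to 1000 nM.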

Compound 4, half-maximal effective concentration: 132 nM
Beside the measured number, compound 4's estimate is 2.3-fold (0.36 log units) above it; low and high end bracket the measured number.
By their numbers in this assay, from the lowest: compound 1; then compound 4; then compounds 3 and 2 (each within the scatter of the next).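

In this assay the side chain proves sensitive to how its atoms are joined: a 2.7-fold lower number from compound 2 to compound 4 (0.43 log units; beyond the scatter) follows from 4-methylphenyl in place of benzyl on a saturated chain carbon, three bonds along the chain from an amide-type nitrogen. For the compounds shown here, the heavy atoms and the single aromatic ring stay the same, so atom content alone does not fix the reading at this position, which the earlier compounds, with no one-place pair among them, could not show. No measurement at hand accounts for this step.

The change also reads as phenethyl to 4-methylbenzyl, and the compounds shown do not separate the effect of the ring methyl from that of the shorter link to the ring. Going by these compounds, how a methoxy group or a chlorine atom in place of that methyl would read also stays open.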